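One more chain carbon on compound 3

The compounds below may be only part of what the source reports. "The series", "measured", "known", "first", "only" and "open" are said of these compounds alone.

In an ADME assay on HepG2 cells (Homo sapiens) for cytotoxicity, read by MTT assay (a lower number here means a stronger inhibitor, a higher number a weaker inhibitor), compound 1 (`COc1ccc(-n2c3cssc-3c(NC(=O)CCCC(=O)c3c(O)cc(C)oc3=O)c2=O)c(OC)c1`) gives 29000 nM, compound 2 (`COc1ccc(-n2c3cssc-3c(NC(=O)OCCOC(=O)CCCCC(=O)c3c(O)cc(C)oc3=O)c2=O)c(OC)c1`) gives 9430 nM and compound 3 (`COc1ccc(-n2c3cssc-3c(NC(=O)N(C)CCOC(=O)CCCC(=O)c3c(O)cc(C)oc3=O)c2=O)c(OC)c1`) gives 5320 nM. Compound 3 lies within the scatter of compound 2, and its number is lower than that of compound 1 by more than the scatter. Compound 4 (`COc1ccc(-n2c3cssc-3c(NC(=O)N(C)CCOC(=O)CCCCC(=O)c3c(O)cc(C)oc3=O)c2=O)c(OC)c1`) differs from compound 3 by a group of 12 heavy atoms (8 carbon, 4 oxygen; one six-membered aromatic ring with 1 hetero atom) in place of a group of 11 heavy atoms (7 carbon, 4 oxygen; one six-membered aromatic ring with 1 hetero atom), on a saturated chain carbon, three bonds along the chain from a carbonyl carbon, on a saturated chain carbon, three bonds along the chain from a carbonyl carbon. For the measured compounds named here, no measured pair isolates this change, so no step beyond the scatter is expected in this assay, in either direction. The estimated step is a 1.1-fold higher number from compound 3 to compound 4 (0.05 log units; within the scatter). For compound 4 the expected value is 6000 nM, with an estimated range of 2500 nM to 14000 nM.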

Compound 4, half-maximal inhibitory concentration: 2760 nM
For compound 4 the middle estimate is 2.2-fold (0.34 log units) above the measured one; measured number inside the range.
By their numbers in this assay, from the lowest: compounds 4, 3 and 2 (each within the scatter of the next, the first and the last beyond it); then compound 1.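

For the compounds shown here, compounds 3 and 4 form the first pair that isolates this change: the group of 12 heavy atoms in place of the group of 11 heavy atoms, on a saturated chain carbon, three bonds along the chain from a carbonyl carbon. In this assay the change gives a 1.9-fold lower number from compound 3 to compound 4 (0.29 log units; within the scatter), so this pair separates no effect of the change at this position. As far as these compounds go, whether a longer chain, an amine or a carboxylic acid at this place would give a step beyond the scatter stays open. No available evidence bears on a cause for this result.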